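Aryl substituent survey on the oxazole ketone series

The compounds below may be only part of what the source reports. "The series", "measured", "known", "first", "only" and "open" are said of these compounds alone.

Measured in an assay (Rattus norvegicus) for inhibition of Fatty-acid amide hydrolase 1 (Homo sapiens); on this read-out higher numbers stand for weaker inhibition and lower numbers for stronger inhibition:
compound 1 `COC(=O)c1ccccc1-c1cnc(C(=O)CCCCCCc2ccccc2)o1`: 60 nM
compound 2 `O=C(CCCCCCc1ccccc1)c1ncc(-c2ccccc2F)o1`: 110 nM
compound 3 `COc1ccccc1-c1cnc(C(=O)CCCCCCc2ccccc2)o1`: 400 nM

Compound 3 stands highest of the three; the nearest is compound 2, with a 3.6-fold higher number from compound 2 to compound 3 (0.56 log units; beyond the scatter), and the furthest compound 1, with a 6.7-fold higher number from compound 1 to compound 3 (0.82 log units; beyond the scatter). Between compounds 1 and 2 the step is a 1.8-fold higher number from compound 1 to compound 2 (0.26 log units; within the scatter).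

Compound 4 `NC(=O)c1cccc(-c2cnc(C(=O)CCCCCCc3ccccc3)o2)c1` differs from compound 3 in 3-carbamoylphenyl in place of 2-methoxyphenyl on an aromatic carbon. For the measured compounds named here, no measured step swaps the aryl group for this one; the steps to compound 3 only show that a change of the aryl substituent moves this assay by modest amounts and that compound 3 sits at the weak end. On that basis a modest move towards stronger inhibition is expected, a 5.0-fold lower number from compound 3 to compound 4 (0.70 log units; beyond the scatter). Compound 4 is therefore estimated at 80 nM, within 20 nM to 350 nM.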

Compound 4, inhibition constant: 6 nM
Beside the measured number, compound 4's estimate is 13-fold (1.12 log units) above it; measured number below the stated range.
By their numbers in this assay, from the lowest: compound 4; then compounds 1 and 2 (each within the scatter of the next); then compound 3.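

In this assay, the aryl group next to the ring oxygen proves able to move the read-out much further than the earlier modest swaps suggested: 3-carbamoylphenyl in place of 2-methoxyphenyl gives a 67-fold lower number from compound 3 to compound 4 (1.82 log units; beyond the scatter), and in place of 2-fluorophenyl it gives an 18-fold lower number from compound 2 to compound 4 (1.26 log units; beyond the scatter). Both steps change the substituent and its place on the phenyl ring together. Nothing at hand accounts for the size of these steps.

As far as these compounds go, whether the gain follows the carbamoyl group itself or its place on the phenyl ring stays open. Also open, from the compounds shown here alone, is whether a carboxylic acid or a nitrile in that place would give a similar number.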